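Arylpiperazine sulfonamides: halogen swap on the phenyl ring

A few compounds are considered here, and "the series" means these few. Any claim that something is new, unique, unknown or untested is made for them only; others in the source may bear on it.

Of the compounds shown here, two have been measured in an assay on CHO cells for displacement of a labelled ligand from adenosine receptor A3 (Homo sapiens), read by scintillation counting, with a stated time of 45 min, tested at 1 uM, in the presence of a further agent that is not named here; a lower number here means less inhibition, a higher number more inhibition at the concentration tested (going by the name of the read-out). Compound 1 `CCCn1c(=O)[nH]c2nc(-c3ccc(S(=O)(=O)N4CCN(c5ccc(Cl)cc5F)CC4)cc3)[nH]c2c1=O` gives 14% in this assay, and compound 2 `CCCn1c(=O)[nH]c2nc(-c3ccc(S(=O)(=O)N4CCN(c5ccccc5F)CC4)cc3)[nH]c2c1=O` gives 9%. Going by the values given here, compound 2 holds the lowest of the two numbers, but its only neighbour is compound 1, and the step of a number 5 percentage points lower from compound 1 to compound 2 (within the scatter) is within the scatter, so the two values cannot be ranked.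

Compound 3 `CCCn1c(=O)[nH]c2nc(-c3ccc(S(=O)(=O)N4CCN(c5ccc(I)cc5)CC4)cc3)[nH]c2c1=O` differs from compound 2 by 4-iodophenyl in place of 2-fluorophenyl on an amine nitrogen in a ring. Among the compounds with values here, the only measured step, a number 5 percentage points lower from compound 1 to compound 2 (within the scatter), touches the same phenyl ring but exchanges a single halogen for hydrogen; the present change replaces the whole halogenated phenyl ring. Going by these compounds, that step was small, so no basis exists for expecting a step beyond the scatter in this assay, though the direction remains open.

Compound 3 is therefore estimated at 12%, within 0% to 30%, an expected step of a number 3 percentage points higher from compound 2 to compound 3 (within the scatter).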

Compound 3, a percentage reported as inhibition, at one concentration (the size of the read-out at that concentration, not a potency): 36%
For compound 3 the middle estimate is 24 percentage points below the measured one; the whole stated range lies below it.
By their numbers in this assay, from the lowest: compounds 2 and 1 (each within the scatter of the next); then compound 3.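

The aryl group on the ring amine nitrogen is a position that can move the read-out in this assay: a number 27 percentage points higher from compound 2 to compound 3 (beyond the scatter) and a number 22 percentage points higher from compound 1 to compound 3 (beyond the scatter), whereas the chloro-to-hydrogen step stayed within the scatter. Both steps keep the heavy-atom count of the 2-fluorophenyl comparison at the same printed level for the leaving and entering groups, and no hydrogen-bond donor or acceptor is gained, so the rise comes with a halogen exchange on a phenyl ring rather than with a larger count of these features. No measurement shown gives a reason for the rise.

Going by these compounds, whether the rise follows the iodine or the loss of the fluorine stays open, since both change together in these steps. A 4-bromophenyl or 4-methoxyphenyl group on the same nitrogen would show whether other groups in that place give a similar read-out.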